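From a bromo to a fluoro aryl on one core

A few compounds are considered here, and "the series" means these few. Any claim that something is new, unique, unknown or untested is made for them only; others in the source may bear on it.

Three compounds share one core, first seen in compound 1 `COc1ccccc1/C=C1\NS(=O)(=O)c2ccccc2C1=O`, which in an assay for inhibition of alkaline phosphatase, tissue-nonspecific isozyme (Homo sapiens), read by spectrophotometry, with stated times of 10 min and 20 min (a lower number here means a stronger inhibitor, a higher number a weaker inhibitor), gives 2590 nM. Compound 2 `COc1cccc(/C=C2\NS(=O)(=O)c3ccccc3C2=O)c1` also carries a methoxy group. In this assay compound 2 gives only > 200000 nM, a limit of the measurement and not a number. The step that the two limits leave unreadable from compound 2 to compound 3 leads to compound 3 `O=C1/C(=C/c2cccc(Br)c2)NS(=O)(=O)c2ccccc21`. In this assay compound 3 likewise gives only the limit > 200000 nM. Compound 3 thus stands where the measurement stops, as two of the three values do according to the limit of > 200000 nM in this assay, at which 2 of the 3 values shown sit, and only compound 1 carries a readable number.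

Compound 4 `O=C1/C(=C/c2ccc(F)cc2)NS(=O)(=O)c2ccccc21` has not yet been measured. It differs from compound 3 in that (4-fluorophenyl in place of 3-bromophenyl on a double-bonded chain carbon bound to a double-bonded ring carbon). For the measured compounds named here, the only measured step touching this region, a step that the two limits leave unreadable from compound 2 to compound 3, cannot be sized because the limit of > 200000 nM in this assay, at which 2 of the 3 values shown sit, holds both of its ends. Going by the values given here, no measured pair separates the exchange of halogen from the change of ring position, so neither part can be weighed. Compound 4 is therefore expected to remain weak in this assay, with an estimated step of an at least 1.3-fold lower number from compound 3 to compound 4 (0.12 log units; that floor lies within the scatter) that may again end at the limit. For compound 4 the expected value is 150000 nM, within 20000 nM to 400000 nM.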

Compound 4, half-maximal inhibitory concentration: 1350 nM
For compound 4 the middle estimate is 110-fold (2.05 log units) above the measured one, and the stated range ends above it.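

In this assay, putting 4-fluorophenyl in place of 3-bromophenyl on a double-bonded chain carbon bound to a double-bonded ring carbon gives an at least 140-fold lower number from compound 3 to compound 4 (2.17 log units; beyond the scatter), so a change at this one place can take a compound from the limit of the measurement to a readable number. For the compounds shown here, until now compound 1, at 2590 nM, was the only compound with a readable number, and compound 4 shows that a methoxy group is not required for one on this core, while compound 2 and compound 3 remain the compounds without a readable number. Compound 3 gives > 200000 nM, which is a limit and not a number, so the step is stated only as a floor: the limit of > 200000 nM in this assay, at which 2 of the 4 values shown sit.

The compounds shown leave open whether the halogen or its ring position carries this step, a question that a 3-fluorophenyl or a 4-bromophenyl group would address. As far as these compounds go, how an amine or a carboxylic acid on the same aromatic ring would read in this assay also stays open.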